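Replacing bromine with a dichlorophenyl ring on an acylguanidine

The source may report more compounds than this note shows. Statements on the series, on what has been measured and on what is new or still open speak of the compounds shown alone.

Measured compounds:
compound 1, `Cc1cc(Br)c(S(C)(=O)=O)cc1C(=O)N=C(N)N`, 12 nM
compound 2, `CS(=O)(=O)c1cc(C(=O)N=C(N)N)c(Cl)cc1Cl`, 140 nM
compound 3, `Cc1c(C(=O)N=C(N)N)cc(S(C)(=O)=O)c(Cl)c1Cl`, 29 nM

All three compounds were tested in a functional assay for inhibition of sodium/hydrogen exchanger (Oryctolagus cuniculus); on this read-out lower numbers stand for stronger inhibition and higher numbers for weaker inhibition. Compound 1 gives the lowest number of the three, and its gaps to compound 3 and to compound 2 both lie beyond the usual scatter, so compound 1 counts as the most potent of the group. No pair among these three differs in only one place, so their values show only that small changes on the shared core move the read-out noticeably.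

The unmeasured compound 4 has the structure `Cc1cc(-c2cc(Cl)cc(Cl)c2)c(S(C)(=O)=O)cc1C(=O)N=C(N)N`. It derives from compound 1 by one change: 3,5-dichlorophenyl in place of bromo on an aromatic carbon. For the measured compounds named here, the group that enters is far larger than the one that leaves, and nothing among the measured compounds shows what such an enlargement does at this position.

For compound 4 in this assay a step from compound 1 of a 2.9-fold higher number from compound 1 to compound 4 (0.46 log units; beyond the scatter) is expected, that is a mild weakening, though a result within the scatter would not surprise. The estimate for compound 4 is 35 nM, expected to fall between 8 nM and 160 nM.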

Compound 4, half-maximal inhibitory concentration: 130 nM
Beside the measured number, compound 4's estimate is 3.7-fold (0.57 log units) below it; low and high end bracket the measured number.
By their numbers in this assay, from the lowest: compound 1; then compound 3; then compounds 4 and 2 (each within the scatter of the next).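

In this assay, putting 3,5-dichlorophenyl in place of bromo gives an 11-fold higher number from compound 1 to compound 4 (1.03 log units; beyond the scatter) and is a large weakening. For the compounds shown here, this is the first comparison in the set that changes only one place, so it shows directly that this aromatic carbon, ortho to a methylsulfonyl group, is sensitive to what it carries, and that this much larger group is a poor exchange for bromo. Even so, compound 4 gives 130 nM as a measured number in this assay and still shows inhibition, so a second aromatic ring at this place weakens the read-out without removing it, and no separate measurement is available to explain the loss.

The compounds shown leave open whether the loss follows from the added ring itself or from its two chlorine atoms, which a plain phenyl ring at the same place would help to separate. They also leave open how groups of intermediate size, such as a methoxy group or a dimethylamino group, would compare with bromo on this carbon.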